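Series notes: the aryl ketone swap from compound 1 to compound 3

The compounds below may be only part of what the source reports. "The series", "measured", "known", "first", "only" and "open" are said of these compounds alone.

In a functional assay on ACHN cells (Homo sapiens) for cytotoxicity, read by sulforhodamine B assay, with a stated time of 48 h, tested at 0.1 uM (on this read-out lower numbers stand for a stronger effect and higher numbers for a weaker effect at the one concentration tested), compound 1 `COc1cc(-c2cc(/C=C/C(=O)c3ccc(N)cc3)[nH]n2)cc(OC)c1OC` gives 97%, and compound 2 `COc1ccc(-c2cc(/C=C/C(=O)c3ccc(OC)c(OC)c3)[nH]n2)cc1` gives 96%; the two numbers lie within the usual scatter of each other, so neither compound stands apart on this read-out, and each sits near the level of no effect at the one concentration tested. Compound 3 `COc1cc(-c2cc(/C=C/C(=O)c3ccc(Cl)c(Cl)c3)[nH]n2)cc(OC)c1OC` has not been measured. It differs from compound 1 by 3,4-dichlorophenyl in place of 4-aminophenyl on a carbonyl carbon. For the measured compounds named here, no measured pair speaks to this change, so the expected step is a number 3 percentage points lower from compound 1 to compound 3 (within the scatter), no larger than the scatter and in no set direction. Compound 3 is estimated at 94%, between 78% and 104%.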

Compound 3, a percentage reported as activity, at one concentration (the size of the read-out at that concentration, not a potency): 105%
Compound 3: middle estimate off by 11 percentage points, on the low side, and the stated range ends below it.
By their numbers in this assay, from the lowest: compounds 2, 1 and 3 (each within the scatter of the next).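

In this assay, the step for 3,4-dichlorophenyl in place of 4-aminophenyl on a carbonyl carbon is a number 8 percentage points higher from compound 1 to compound 3 (within the scatter). This position therefore tolerates the exchange of a group with a hydrogen-bond donor and acceptor for one with neither, and compound 3, like compound 1, stays near the level of no effect at the one concentration tested. Nothing available gives a reason for this result.

From the compounds shown here alone, it remains open whether a carboxylic acid or a morpholine on that carbonyl carbon would lower the number. The behaviour of these compounds at other concentrations also remains open.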